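The source may report more compounds than this note shows. Statements on the series, on what has been measured and on what is new or still open speak of the compounds shown alone.

Compound 1 `Cc1ccc(C)c(-n2nncc2CN2C(=O)C3(C(C#N)=C(N)Oc4c3c3nc5ccccc5nc3c3ccccc43)c3ccccc32)c1` gives only a limit, not a number, in a functional assay on HepG2 cells (Homo sapiens) for antiproliferative activity, read by MTT assay, with a stated time of 48 h; on this read-out higher numbers stand for weaker inhibition and lower numbers for stronger inhibition: > 50000 nM.
Compound 2 `Cc1cc(C)cc(-n2nncc2CN2C(=O)C3(C(C#N)=C(N)Oc4c3c3nc5ccccc5nc3c3ccccc43)c3ccccc32)c1` likewise gives only a limit in this assay: > 50000 nM.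
Compound 3 `Cc1ccc(C)c(-n2nncc2CN2C(=O)C3(C(C#N)=C(N)Oc4c(N)cc5nc6ccccc6nc5c43)c3ccccc32)c1` again gives only a limit in this assay: > 50000 nM.

The step from compound 1 to compound 2 is the change (3,5-dimethylphenyl in place of 2,5-dimethylphenyl on an aromatic nitrogen). Its size, a step that the two limits leave unreadable from compound 1 to compound 2, cannot be read because the limit of > 50000 nM in this assay, at which 3 of the 3 values shown sit, holds for both. How the cores of compound 1 and compound 3 differ is not broken down here. Compound 4 `Cc1cc(C)cc(-n2nncc2CN2C(=O)C3(C(C#N)=C(N)Oc4c(N)cc5nc6ccccc6nc5c43)c3ccccc32)c1` remains to be measured; it differs from compound 3 by 3,5-dimethylphenyl in place of 2,5-dimethylphenyl on an aromatic nitrogen, the same change as from compound 1 to compound 2 and at a place described in the same words. Compound 4 is expected to show a step that the limit leaves unreadable from compound 3 to compound 4, an expectation that rests on compound 2 giving > 50000 nM in this assay after the same change. For compound 4 the estimate in this assay is 80000 nM, expected between 20000 nM and 300000 nM, most likely again reported only as a limit.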

Compound 4, half-maximal inhibitory concentration: > 50000 nM
Compound 4 was reported as a limit; the forecaster's own chance of this, stated with the estimate: 85%; the middle value lies beyond the limit too.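

No size can be read for the step from compound 3 to compound 4, because both compounds give only a limit: the limit of > 50000 nM in this assay, at which 4 of the 4 values shown sit. The compounds shown leave open whether 2,5-dimethylphenyl and 3,5-dimethylphenyl differ at all in this assay.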